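Fluorines on the Phenyl Ring: An Expected Value

A few compounds are considered here, and "the series" means these few. Any claim that something is new, unique, unknown or untested is made for them only; others in the source may bear on it.

Compound 2 `COc1cc2c(Oc3ccc(NC(=O)c4cn(-c5ccccc5)nn4)cc3F)ccnc2cc1OCCCN1CCCCC1` and compound 1 `COc1cc2c(Oc3ccc(NC(=O)c4cn(-c5ccc(Br)cc5)nn4)cc3F)ccnc2cc1OCCCN1CCCC1` share a core and were both tested in a functional assay on HT-29 cells (Homo sapiens) for cytotoxicity, read by MTT assay, with a stated time of 72 h; on this read-out lower numbers stand for stronger inhibition and higher numbers for weaker inhibition. In this assay compound 2 gives 180 nM, and compound 1 gives 190 nM; these two numbers lie within the usual scatter of each other, so compound 2 stands lowest of the two without being separable from compound 1. The two compounds differ in more than one place, so nothing beyond what the two values show is drawn from that pair. Compound 3 `COc1cc2c(Oc3ccc(NC(=O)c4cn(-c5ccc(F)c(F)c5)nn4)cc3F)ccnc2cc1OCCCN1CCCCC1` carries 3,4-difluorophenyl in place of phenyl on an aromatic nitrogen. Among the compounds with values here, no single-point step between measured compounds is known, so the change is expected to bring a step of a 1.1-fold lower number from compound 2 to compound 3 (0.02 log units; within the scatter), with no direction beyond the scatter. Compound 3 is therefore estimated to give about 170 nM in this assay, within a range from 80 nM to 380 nM.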

Compound 3, half-maximal inhibitory concentration: 210 nM
Compound 3: the middle estimate sits 1.2-fold (0.09 log units) below what was measured, within the range that was stated.
By their numbers in this assay, from the lowest: compounds 2, 1 and 3 (each within the scatter of the next).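

Placing 3,4-difluorophenyl in place of phenyl on an aromatic nitrogen gives the first reading of a single change at this position: in this assay it brings a 1.2-fold higher number from compound 2 to compound 3 (0.07 log units; within the scatter) on the cytotoxicity read-out. In this one pair, the phenyl on that nitrogen can therefore take the two fluorines without a shift that can be told from the usual scatter. No measurement at hand accounts for this result.

Going by these compounds, whether this insensitivity extends to other groups remains open, since a single pair with fluorine as the only added atom cannot show it. A methoxy group, an amine or a carboxylic acid on this phenyl, or a pyridine in its place, could still move the number beyond the scatter.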